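From Methoxyethyl Ester to Pentyl Ester: Expected Cytotoxicity

The compounds below may be only part of what the source reports. "The series", "measured", "known", "first", "only" and "open" are said of these compounds alone.

Compound 2 `COCCOC(=O)C(O)Cn1cnc2c(N)ncnc21` was tested in a functional assay on Vero cells (Chlorocebus sabaeus) for cytotoxicity; on this read-out higher numbers stand for lower toxicity in this test and lower numbers for higher toxicity in this test. In this assay compound 2 gives > 400 ug/mL, which is a limit of the assay rather than a number. Compound 1 `Nc1ncnc2c1ncn2CC(O)C(=O)OCCO` in this assay gives > 400 ug/mL, also a limit. Between these two compounds lies a step that the two limits leave unreadable from compound 1 to compound 2, unreadable because of the limit of > 400 ug/mL in this assay, at which 2 of the 2 values shown sit. Compound 3 `CCCCCOC(=O)C(O)Cn1cnc2c(N)ncnc21` differs from compound 2 by propyl in place of methoxy on a saturated chain carbon, two bonds along the chain from an oxygen next to a carbonyl group. Among the compounds with values here, no measured step shows a readable size, so no shift beyond the scatter can be expected in either direction. Compound 3 is therefore expected to give 400 ug/mL, with a range from 200 ug/mL to 400 ug/mL. The estimated step is a number no higher from compound 2 to compound 3 (the limit leaves the size open).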

Compound 3, minimum cytotoxic concentration: 200 ug/mL
Compound 3: middle estimate off by 2.0-fold (0.30 log units), on the high side; measured number inside the range.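

Among the compounds shown, only compound 3 gives a number rather than a limit in this assay, so this position now has one measured reading. Propyl in place of methoxy gives an at least 2.0-fold lower number from compound 2 to compound 3 (0.30 log units; that floor lies within the scatter), and propyl in place of hydroxy gives an at least 2.0-fold lower number from compound 1 to compound 3 (0.30 log units; that floor lies within the scatter). Neither floor goes beyond the scatter, and the true size of each step stays open: the limit of > 400 ug/mL in this assay, at which 2 of the 3 values shown sit.

The compounds shown leave open whether a longer chain, such as octyl, or an amine in place of propyl would give a clearly lower number.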